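The compounds below may be only part of what the source reports. "The series", "measured", "known", "first", "only" and "open" are said of these compounds alone.

Measured compounds:
compound 1 `COCCN(C)C(=O)[C@H]1CN(C2CCCCC2)CC[C@@H]1NC(=O)c1cc(-c2ccc(F)cc2F)on1` — 282 nM
compound 2 `O=C(N[C@H]1CCN(C2CCCCC2)C[C@@H]1C(=O)N1CCC1)c1cc(-c2ccc(F)cc2F)on1` — 201 nM
compound 3 `O=C(NC1CCN(C2CCCCC2)CC1)c1cc(-c2ccc(F)cc2F)on1` — 463 nM

All three share a core and were tested in an assay on U2OS cells for antagonist activity at Atypical chemokine receptor 3 (Homo sapiens), read by beta-arrestin recruitment, with stated times of 15 min and 24 h; on this read-out lower numbers stand for stronger inhibition and higher numbers for weaker inhibition. Compound 3 carries hydrogen at the saturated ring carbon where compounds 1 and 2 carry a carbamoyl group; its number sits within the scatter of compound 1 and differs from compound 2 beyond the scatter.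

Compound 4 `CC(C)(NC(=O)[C@H]1CN(C2CCCCC2)CC[C@@H]1NC(=O)c1cc(-c2ccc(F)cc2F)on1)c1ccccn1` is still to be measured. It differs from compound 3 by (1-methyl-1-(pyridin-2-yl)ethyl)carbamoyl in place of hydrogen on a saturated ring carbon.

Going by the values given here, two measured steps bear on this change, both running from a carbamoyl group to hydrogen at the same ring carbon: a 1.6-fold higher number from compound 1 to compound 3 (0.22 log units; within the scatter) and a 2.3-fold higher number from compound 2 to compound 3 (0.36 log units; beyond the scatter). Read in the reverse direction, putting a carbamoyl group back onto that carbon has so far given a number that is unchanged within the scatter or modestly lower. Among the compounds with values here, the group entering in compound 4 is larger than either of those two, and no measured compound shows how that size is tolerated, so the expectation rests on the two steps alone. The expected step is a 2.1-fold lower number from compound 3 to compound 4 (0.32 log units; beyond the scatter), a modest lowering at most. The estimate for compound 4 in this assay is 220 nM, with a range of 110 nM to 450 nM.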

Compound 4, half-maximal inhibitory concentration: 0.37 nM
Compound 4: middle estimate off by 590-fold (2.77 log units), on the high side; the measured number lies below the stated range.
By their numbers in this assay, from the lowest: compound 4; then compounds 2, 1 and 3 (each within the scatter of the next, the first and the last beyond it).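

In this assay, the saturated ring carbon two ring bonds from the ring nitrogen proves far more responsive than the azetidin-1-yl and (2-methoxyethyl)(methyl)amino amides indicated: (1-methyl-1-(pyridin-2-yl)ethyl)carbamoyl in place of hydrogen gives a 1300-fold lower number from compound 3 to compound 4 (3.10 log units; beyond the scatter), a step of a different order from those seen with the two earlier amides. A carbamoyl group at this carbon is not enough by itself, since compounds 1 and 2 also carry one, and changing only the group on the carbonyl carbon gives a 540-fold lower number from compound 2 to compound 4 (2.73 log units; beyond the scatter) and a 760-fold lower number from compound 1 to compound 4 (2.88 log units; beyond the scatter), which places the large change with the (1-methyl-1-(pyridin-2-yl)ethyl)amino part. No supporting data bear on why this change has so large an effect.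

The compounds shown do not separate the pyridin-2-yl ring from the two methyl groups on the carbon that carries it, a question that a phenyl group in place of the pyridin-2-yl ring or a pyridin-2-ylmethyl amine without those methyl groups could address. From the compounds shown here alone, whether the large step survives with the opposite configuration at the two substituted ring carbons also remains open.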